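This account rests on a few compounds, and the source may have more. Where it says the series, first, only, none or still open, it means among the compounds named here.

In an ADME assay on MDBK cells (Bos taurus) for cytotoxicity (a higher number here means that more compound is tolerated, a lower number that less compound is tolerated), compound 1 (`Fc1ccc(Cn2ccc3nc(-c4ccccc4)nc-3c2)cc1`) gives > 100000 nM, which is a limit of the assay and not a number. Compound 2 (`N#Cc1cccc(Cn2ccc3nc(-c4ccccc4)nc-3c2)c1`) gives > 100000 nM, which is also a limit. Both measured compounds therefore sit at the same ceiling, as the limit of > 100000 nM in this assay, at which 2 of the 2 values shown sit, shows, and compound 1 has no exact value to start from. Compound 3 (`c1ccc(-c2ccc(Cn3ccc4nc(-c5ccccc5)nc-4c3)cc2)cc1`) carries phenyl in place of fluoro on an aromatic carbon, para to a large group: phenyl in place of fluoro on an aromatic carbon. For the measured compounds named here, the only measured step that bears on this change is a step that the two limits leave unreadable from compound 1 to compound 2, so it offers no size to carry over. The change to compound 3 is a different one, and the data do not show how it will behave. A small move toward less compound tolerated is expected, perhaps none beyond the scatter, and the estimated step is an at least 1.4-fold lower number from compound 1 to compound 3 (0.15 log units; that floor lies within the scatter). For compound 3 the estimated value is 70000 nM, with an expected range from 20000 nM to 100000 nM.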

Compound 3, half-maximal cytotoxic concentration: 18000 nM
The estimate for compound 3 lay 3.9-fold (0.59 log units) above the measured number, outside the stated range (below it).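

Phenyl in place of fluoro on this aromatic carbon, para to a large group, gives an at least 5.5-fold lower number from compound 1 to compound 3 (0.74 log units; beyond the scatter), so a change at this place can move the result in this assay beyond the scatter. The step between compound 1 and compound 2 cannot be read, which makes this the first change shown with any readable size, and compound 3 the first compound with an exact value. Only a lower bound on that size is known, since the comparison starts from a limit: the limit of > 100000 nM in this assay, at which 2 of the 3 values shown sit.

This single step leaves open whether the drop belongs to phenyl alone or extends to other groups on this carbon. A methoxy group, an amine or a carboxylic acid here would show whether the tolerated amount follows the size of the group or its kind.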